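The compounds below may be only part of what the source reports. "The series", "measured", "known", "first", "only" and "open" are said of these compounds alone.

The compounds measured so far:
compound 1, `Cc1c(C(=O)N/N=C\c2ccccc2F)oc2cccc(O)c12`, >= 40000 nM
compound 2, `Cc1c(C(=O)N/N=C\c2cccc(F)c2O)oc2cccc(O)c12`, 12700 nM

Compound 1 and compound 2 share one core and differ only in the aromatic ring attached to the carbon that carries a double bond to nitrogen. In a functional assay on PC-3 cells (Homo sapiens) for inhibition (a higher number here means a weaker inhibitor, a lower number a stronger inhibitor), compound 1 gives >= 40000 nM, which is a limit of the assay rather than a number (the limit of >= 40000 nM in this assay, at which 1 of the 2 values shown sits). For the measured compounds named here, compound 2, with a 3-fluoro-2-hydroxyphenyl in place of the 2-fluorophenyl, gives 12700 nM in this assay, the only true number among the values shown. The step of an at least 3.1-fold lower number from compound 1 to compound 2 (0.49 log units; beyond the scatter) shows that this exchange lowered the number. Compound 3 is `Cc1c(C(=O)N/N=C\c2cc(O)ccc2O)oc2cccc(O)c12`; it differs from compound 2 by 2,5-dihydroxyphenyl in place of 3-fluoro-2-hydroxyphenyl on a carbon with a double bond to nitrogen. The hydroxy that entered in compound 2 stays, and the fluorine gives way to a second hydroxy. Going by the values given here, only the step from compound 1 to compound 2 bears on this change, and it pointed toward lower numbers when a hydroxy entered, so a modest move in the same direction, or none beyond the scatter, is expected. Compound 3 is therefore estimated at 8000 nM, within 2500 nM to 25000 nM, a step of a 1.6-fold lower number from compound 2 to compound 3 (0.20 log units; within the scatter).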

Compound 3, half-maximal inhibitory concentration: 95500 nM
Compound 3: middle estimate off by 12-fold (1.08 log units), on the low side, outside the stated range (above it).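

In this assay, the exchange of 3-fluoro-2-hydroxyphenyl for 2,5-dihydroxyphenyl on the carbon with a double bond to nitrogen gives a 7.5-fold higher number from compound 2 to compound 3 (0.88 log units; beyond the scatter). The number therefore moved up, against the direction of the earlier step, so this position does not simply reward an extra hydroxy: compound 2 fits that idea, while compound 3 goes against it. The step from compound 1 to compound 3 cannot be read, because the entry for compound 1 is a limit and not a number: the limit of >= 40000 nM in this assay, at which 1 of the 3 values shown sits.

The step from compound 2 to compound 3 removes the fluorine and brings in the second hydroxy at once, so the compounds shown cannot tell which of the two events moved the number, or whether both did. As far as these compounds go, it also remains open how this position would respond to a methoxy group, a chlorine or an amine on the ring, and whether any such group would give a lower number than compound 2, which gives 12700 nM.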